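The source may hold more compounds than are shown below. What is called first, only, known or untested is meant among the compounds shown, and "the series" means these compounds.

In an assay for inhibition of NAD-dependent protein deacylase sirtuin-6 (Homo sapiens), read by HPLC, with stated times of 15 min and 1 h, tested at 333 uM (on this read-out lower numbers stand for less inhibition and higher numbers for more inhibition at the one concentration tested (going by the name of the read-out)), compound 1 `CCCCNC(=O)CCCSC[C@H](NC(=O)OCc1ccccc1)C(=O)Nc1ccccc1` gives 26%, compound 2 `NC(=O)CCCSC[C@H](NC(=O)OCc1ccccc1)C(=O)Nc1ccccc1` gives 11%, and compound 3 `CCCCCCNC(=O)CCCSC[C@H](NC(=O)OCc1ccccc1)C(=O)Nc1ccccc1` gives "not active" (no number reported), a reported verdict with no number attached. Compound 3 therefore stands without a figure of its own, beneath the two compounds that have one in this assay. Compound 4 `CNC(=O)CCCSC[C@H](NC(=O)OCc1ccccc1)C(=O)Nc1ccccc1` differs from compound 3 by hydrogen in place of pentyl on a saturated chain carbon bound to an amide-type nitrogen. Among the measured compounds shown here, the one measured step of this kind, a number 15 percentage points lower from compound 1 to compound 2 (beyond the scatter), moved the read-out down when the chain was taken away, whereas compound 3, which carries the hexyl chain, is reported as not active; so no firm direction follows, and a low read-out near that of compound 2 is expected. Compound 4 is estimated at 15%, within 0% to 30%.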

Compound 4, a percentage reported as inhibition, at one concentration (the size of the read-out at that concentration, not a potency): "not active" (no number reported)
No number was reported for compound 4, and the estimate cannot be compared.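

Compound 3 and compound 4 are both reported as not active, without a number, so no step can be read between them. On these data alone, how the length of the chain on the amide-type nitrogen affects the read-out stays open. No further evidence bears on this result.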